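This account rests on a few compounds, and the source may have more. Where it says the series, first, only, none or still open, it means among the compounds named here.

Measured in a functional assay on DLD-1 cells (Homo sapiens) for cytotoxicity, read by WST assay, with a stated time of 72 h; a higher number here means a weaker inhibitor, a lower number a stronger inhibitor:
- compound 1 `COc1cc2c(Nc3nc4ccc(C(=O)Nc5c(C)cccc5C)cc4s3)ncnc2cc1OCCCN1CCCC1`: > 100000 nM
- compound 2 `CCN(CC)CCCOc1cc2ncnc(Nc3nc4ccc(C(=O)Nc5c(C)cccc5C)cc4s3)c2cc1OC`: > 100000 nM
- compound 3 `COc1cc2c(Nc3nc4ccc(C(=O)Nc5c(C)cccc5C)cc4s3)ncnc2cc1OCCCN1CCCCC1`: > 100000 nM

Each entry is a limit and not a number. Compound 2 stands at > 100000 nM, which is a limit. It shares this position with the other two compounds: the limit of > 100000 nM in this assay, at which 3 of the 3 values shown sit.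

Compound 4 `CCN(CC)CCCOc1cc2ncnc(Nc3nc4ccc(C(=O)Nc5c(C)cc(C)cc5C)cc4s3)c2cc1OC` differs from compound 2 by methyl in place of hydrogen on an aromatic carbon. This is methyl in place of hydrogen on an aromatic carbon, para to a large group, turning 2,6-dimethylphenyl into 2,4,6-trimethylphenyl.

The measured steps change only the amine on the chain, so they bear on this change only indirectly: a step that the two limits leave unreadable from compound 1 to compound 2, a step that the two limits leave unreadable from compound 1 to compound 3 and a step that the two limits leave unreadable from compound 2 to compound 3. None gives a size, and the series holds no measured change at the aromatic ring. Going by these compounds, no step beyond the scatter is therefore expected in this assay, and the direction stays open. The expected step is a number no higher from compound 2 to compound 4 (the limit leaves the size open). Compound 4 is estimated at 100000 nM, with an expected range of 20000 nM to 100000 nM.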

Compound 4, half-maximal inhibitory concentration: 6800 nM
The estimate for compound 4 lay 15-fold (1.17 log units) above the measured number; the measured number lies below the stated range.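

In this assay, turning 2,6-dimethylphenyl into 2,4,6-trimethylphenyl gives an at least 14-fold lower number from compound 2 to compound 4 (1.16 log units; beyond the scatter), so this aromatic carbon, para to a large group, is a place where a single methyl moves the read-out. For the compounds shown here, the steps among the pyrrolidin-1-yl, diethylamino and piperidin-1-yl amines cannot be read, which leaves this methyl as the only change with a readable size. Compound 4 alone has a number, while the other compounds remain at a limit of the assay: the limit of > 100000 nM in this assay, at which 3 of the 4 values shown sit.

Going by these compounds, it stays open whether another group on this carbon, such as ethyl, methoxy or chloro, would act as methyl does here. On these data alone, it is also open whether 2,4,6-trimethylphenyl would give a comparable step with pyrrolidin-1-yl or piperidin-1-yl on the chain in place of diethylamino.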